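Amide nitrogen aryl variation, compound 2 to compound 3

A few compounds are considered here, and "the series" means these few. Any claim that something is new, unique, unknown or untested is made for them only; others in the source may bear on it.

Measured compounds:
- compound 1, `Cc1cc(F)ccc1N(C)C(=O)c1ccc(-c2ccc(O)cc2)o1`: in an assay on T47D cells for inhibition of 17-beta-hydroxysteroid dehydrogenase type 1 (Homo sapiens), read by HPLC, with a stated time of 24 h (on this read-out lower numbers stand for stronger inhibition and higher numbers for weaker inhibition), compound 1 gives 7.6 nM
- compound 2, `Cc1ccncc1N(C)C(=O)c1ccc(-c2ccc(O)cc2)o1`: in this assay compound 2 gives 64 nM

Among the compounds with values here, compound 2 holds the higher of the two numbers in this assay; its only neighbour is compound 1, and the step of an 8.4-fold higher number from compound 1 to compound 2 (0.93 log units; beyond the scatter) is the single measured step, with 4-methylpyridin-3-yl in place of 4-fluoro-2-methylphenyl on the amide-type nitrogen.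

Compound 3, `Cc1ncccc1N(C)C(=O)c1ccc(-c2ccc(O)cc2)o1`, is not yet measured. It differs from compound 2 by 2-methylpyridin-3-yl in place of 4-methylpyridin-3-yl on an amide-type nitrogen. The methyl in 2-methylpyridin-3-yl is named as in the 4-fluoro-2-methylphenyl of compound 1, while the ring nitrogen stays as in compound 2. Within the data shown here, the one measured step bears only loosely on this: it exchanged the ring atoms and the methyl naming together with loss of the fluorine, so the share of the methyl naming in an 8.4-fold higher number from compound 1 to compound 2 (0.93 log units; beyond the scatter) cannot be separated. Going by these compounds, a small move back toward compound 1 is plausible, but a step within the scatter is equally open; in this assay the expected step is a 1.8-fold lower number from compound 2 to compound 3 (0.26 log units; within the scatter). For compound 3 the estimate in this assay is 35 nM, expected between 9 nM and 130 nM.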

Compound 3, half-maximal inhibitory concentration: 43 nM
Estimate against measurement, compound 3: 1.2-fold (0.09 log units) below; the range from low to high includes it.
By their numbers in this assay, from the lowest: compound 1; then compounds 3 and 2 (each within the scatter of the next).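

In this assay, 2-methylpyridin-3-yl in place of 4-methylpyridin-3-yl on the amide-type nitrogen gives a 1.5-fold lower number from compound 2 to compound 3 (0.17 log units; within the scatter), so this rearrangement of the same atoms does not separate the two compounds. The methyl naming shared with the 4-fluoro-2-methylphenyl of compound 1 does not close the earlier gap either: the change gives a 5.7-fold higher number from compound 1 to compound 3 (0.75 log units; beyond the scatter), which leaves both methylpyridin-3-yl groups beyond the scatter from compound 1. Nothing shown here accounts for either step.

Compound 1 and compound 3 still differ in two features, the ring nitrogen and the fluorine, so the share of each in the step between them cannot be separated, and a plain 2-methylphenyl group on the amide-type nitrogen would divide the two. Also open, going by these compounds, is how far the similarity of compound 2 and compound 3 extends to other groups on the same ring, such as a methoxy group or a chlorine in place of the methyl of 2-methylpyridin-3-yl.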